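This account rests on a few compounds, and the source may have more. Where it says the series, first, only, none or still open, it means among the compounds named here.

In a physicochemical assay for acid dissociation, compound 3 `COc1cccc(CNCCCNc2ccnc3cc(Cc4ccc(F)cc4Cl)ccc23)c1O` gives 9.47, the largest of the three numbers, yet compound 1 `COc1ccccc1Oc1ccc2c(NCCCNCc3ccco3)ccnc2c1` gives 9.28 and compound 2 `COc1cccc(CNCCCNc2ccnc3cc(Oc4ccc(Cl)cc4)ccc23)c1O` gives 9.28, each within the usual scatter of it. Among the compounds with values here, the one measured step, a number 0.19 log units higher from compound 2 to compound 3 (within the scatter), exchanged one group on the shared core for another and stayed within the scatter. Compound 4 `COc1ccccc1Oc1ccc2c(NCCCNCc3cccc(OC)c3O)ccnc2c1` differs from compound 3 by 2-methoxyphenoxy in place of 2-chloro-4-fluorobenzyl on an aromatic carbon. Within the data shown here, the group that enters is the one compound 1 already carries at this position, and since swapping groups here produced only a number 0.19 log units higher from compound 2 to compound 3 (within the scatter), no shift beyond the scatter is expected. The estimated step is therefore a number 0.17 log units lower from compound 3 to compound 4 (within the scatter). Compound 4 is expected to give 9.3, between 9 and 9.6.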

Compound 4, acid dissociation constant: 9.28
The estimate for compound 4 lay 0.02 log units above the measured number; the range from low to high includes it.
By their numbers in this assay, from the lowest: compounds 1, 2, 4 and 3 (each within the scatter of the next).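

In this assay, placing 2-methoxyphenoxy on the aromatic carbon in place of 2-chloro-4-fluorobenzyl gives a number 0.19 log units lower from compound 3 to compound 4 (within the scatter) and so, like the earlier swap there, leaves the number within the scatter. On the oxygen, 2-methoxyphenyl in place of 4-chlorophenyl gives no change at the digits printed from compound 2 to compound 4 (within the scatter) while 2-hydroxy-3-methoxyphenyl in place of furan-2-yl on the saturated chain carbon gives no change at the digits printed from compound 1 to compound 4 (within the scatter) and thus extends this picture to two further places. Nothing measured here accounts for how closely these numbers agree. On these data alone, whether a carboxylic acid or an amine on this aromatic carbon, or a longer chain, would move the number beyond the scatter stays open.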